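A few compounds are considered here, and "the series" means these few. Any claim that something is new, unique, unknown or untested is made for them only; others in the source may bear on it.

For the measured compounds named here, of the two compounds measured so far, compound 1 `N#C[Se]c1ccc(NC(=O)OCc2ccc([N+](=O)[O-])cc2)cc1` and compound 2 `N#C[Se]c1ccc(NC(=O)Oc2ccc(F)cc2)cc1` sit at numbers within the scatter of each other: in a functional assay on CCRF-CEM cells (Homo sapiens) for cytotoxicity, read by MTT assay, with a stated time of 72 h (a lower number here means that less compound is tolerated, a higher number that more compound is tolerated), compound 1 gives 68800 nM, and compound 2 gives 71100 nM, so neither can be called more or less tolerated than the other. Compound 3 `N#C[Se]c1ccc(NC(=O)OCc2ccccc2)cc1` differs from compound 1 by hydrogen in place of nitro on an aromatic carbon. Going by the values given here, no step between measured compounds shows what this kind of change does in this assay, so no shift beyond the scatter is expected. The estimated step of a 1.0-fold higher number from compound 1 to compound 3 (0.01 log units; within the scatter) is small. Compound 3 is expected to give about 70000 nM, most likely between 35000 nM and 140000 nM.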

Compound 3, concentration lethal to 50% of the cells: 73700 nM
Estimate against measurement, compound 3: 1.1-fold (0.02 log units) below; measured number inside the range.
By their numbers in this assay, from the lowest: compounds 1, 2 and 3 (each within the scatter of the next).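

Putting hydrogen in place of nitro on this aromatic carbon, para to a large group, gives a 1.1-fold higher number from compound 1 to compound 3 (0.03 log units; within the scatter) in this assay. For the compounds shown here, this is the first direct reading of the change, and it shows that compound 1 and compound 3 cannot be told apart in this assay, with or without the nitro group at this position. Nothing measured here offers an explanation for this result. Going by these compounds, whether an amine, a carboxylic acid or a methoxy group on the same carbon would behave alike remains open.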